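Replacing a Difluorophenyl with a Methoxyphenyl in Compound 4

A few compounds are considered here, and "the series" means these few. Any claim that something is new, unique, unknown or untested is made for them only; others in the source may bear on it.

Measured compounds in an ADME assay on HT-29 cells (Homo sapiens) for inhibition, read by MTT assay, with a stated time of 72 h; a lower number here means a stronger inhibitor, a higher number a weaker inhibitor:
compound 1 `C=CC(=O)Nc1cccc(Nc2nc(N/N=C/c3ccccc3F)ncc2Cl)c1` gives 3500 nM
compound 2 `C=CC(=O)Nc1cccc(Nc2nc(N/N=C/c3ccc(F)cc3F)ncc2Cl)c1` gives 4760 nM
compound 3 `C=CC(=O)Nc1cccc(Nc2nc(N/N=C(\C)c3ccc(F)cc3F)ncc2Cl)c1` gives 4360 nM

Compound 3 holds the second highest of the three numbers; its nearest neighbour is compound 2, and its gap to compound 1 is also within the scatter, so none of the three can be told apart on these numbers. Compound 4 `C=CC(=O)Nc1cccc(Nc2nc(N/N=C(\C)c3ccc(OC)cc3)ncc2Cl)c1` differs from compound 3 in one place: 4-methoxyphenyl in place of 2,4-difluorophenyl on a carbon with a double bond to nitrogen. Among the compounds with values here, the only measured step, a 1.4-fold higher number from compound 1 to compound 2 (0.13 log units; within the scatter), added a fluorine on an aromatic carbon and stayed within the scatter. Within the data shown here, no measured step removes fluorines or introduces a methoxy group, so that step bears on the change only loosely. With the three values lying close together and no step beyond the scatter among them, the writer expects compound 4 to stay near compound 3, an expected step of a 1.1-fold lower number from compound 3 to compound 4 (0.04 log units; within the scatter) in this assay. Compound 4 is therefore estimated at 4000 nM, with a range from 1500 nM to 11000 nM.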

Compound 4, half-maximal inhibitory concentration: 4560 nM
Beside the measured number, compound 4's estimate is 1.1-fold (0.06 log units) below it, within the range that was stated.
By their numbers in this assay, from the lowest: compounds 1, 3, 4 and 2 (each within the scatter of the next).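

In this assay the exchange of 2,4-difluorophenyl for 4-methoxyphenyl on a carbon with a double bond to nitrogen gives a 1.0-fold higher number from compound 3 to compound 4 (0.02 log units; within the scatter) and so stays within the scatter. The earlier step added one fluorine to the ring, whereas this one removes both fluorines and brings in a methoxy group with its hydrogen-bond acceptor, and even this larger exchange at this place yields numbers that cannot be told apart. No available evidence bears on why the number holds across this change.

The compounds shown leave open whether a ring carrying an amine or a carboxylic acid at this place would give a step beyond the scatter. They also leave open whether a longer chain in place of the saturated chain carbon on this same carbon would do so.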